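This account rests on a few compounds, and the source may have more. Where it says the series, first, only, none or still open, it means among the compounds named here.

In a functional assay on MCF cells (Homo sapiens) for antiproliferative activity, with a stated time of 72 h (on this read-out higher numbers stand for weaker inhibition and lower numbers for stronger inhibition), three compounds sharing one core have been tested so far. Compound 1 `OC[C@H]1O[C@@H](n2cnc3c(NCc4ccc(Cl)cc4)ncnc32)[C@H](O)[C@@H]1O` gives > 166000 nM, which is a limit of the assay and not a number. Compound 2 `OC[C@H]1O[C@@H](n2cnc3c(NCc4ccc(F)c(F)c4F)ncnc32)[C@H](O)[C@@H]1O` gives > 166000 nM, again only a limit. Compound 3 `OC[C@H]1O[C@@H](n2cnc3c(NCc4ccc(F)c(Cl)c4)ncnc32)[C@H](O)[C@@H]1O` gives > 166000 nM, also only a limit. Compound 3 therefore has no exact value, and the whole set shares one result: the limit of > 166000 nM in this assay, at which 3 of the 3 values shown sit.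

The next compound, compound 4 `Cc1cccc(CNc2ncnc3c2ncn3[C@@H]2O[C@H](CO)[C@@H](O)[C@H]2O)c1O`, differs from compound 3 in a single group: 2-hydroxy-3-methylphenyl in place of 3-chloro-4-fluorophenyl on a saturated chain carbon bound to a nitrogen on an aromatic ring. Here 2-hydroxy-3-methylphenyl stands in place of 3-chloro-4-fluorophenyl, on a saturated chain carbon bound to a nitrogen on an aromatic ring.

The measured steps at this same place are a step that the two limits leave unreadable from compound 1 to compound 2, a step that the two limits leave unreadable from compound 1 to compound 3 and a step that the two limits leave unreadable from compound 2 to compound 3. None of them has a readable size, so they offer no size to carry over to the new group. The entering group also differs from all three tested groups, which leaves the forecast loose. No step beyond the scatter is expected in this assay, in either direction, and the most likely report is the same limit again. The expected change is a number no higher from compound 3 to compound 4 (the limit leaves the size open). The estimated value for compound 4 is 166000 nM, with an expected range from 60000 nM to 300000 nM.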

Compound 4, half-maximal inhibitory concentration: 6900 nM
Compound 4: the middle estimate sits 24-fold (1.38 log units) above what was measured; measured number below the stated range.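

In this assay, for the compounds shown here, 2-hydroxy-3-methylphenyl is the first group at this place, on a saturated chain carbon bound to a nitrogen on an aromatic ring, to give a readable number, and the change is large whichever halogen-bearing phenyl group it replaces: an at least 24-fold lower number from compound 3 to compound 4 (1.38 log units; beyond the scatter), an at least 24-fold lower number from compound 2 to compound 4 (1.38 log units; beyond the scatter) and an at least 24-fold lower number from compound 1 to compound 4 (1.38 log units; beyond the scatter). The steps among compound 1, compound 2 and compound 3 cannot be read, so this position looked silent until now, yet the new result shows that the group held there can matter a great deal. Compound 4 also brings the only hydrogen-bond donor and acceptor in this group of compounds, and it alone stands off the shared limit: the limit of > 166000 nM in this assay, at which 3 of the 4 values shown sit.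

The entering group differs from the others in more than one way, so the compounds shown do not tell whether the hydroxy, the methyl or the two together go with the lower number; 2-hydroxyphenyl and 3-methylphenyl at this place would separate them. Nor do they show whether a methoxy group or an amine in place of the hydroxy would keep the number this low.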